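The source may report more compounds than this note shows. Statements on the series, on what has been measured and on what is new or still open speak of the compounds shown alone.

Measured compounds so far:
Compound 1 `O=C(/C=C\Nc1cnc2ccccc2c1)c1nc(-c2ccccc2)n2ccccc12`: in a functional assay on A549 cells (Homo sapiens) for cytotoxicity, read by MTT assay, with a stated time of 48 h (on this read-out higher numbers stand for weaker inhibition and lower numbers for stronger inhibition), compound 1 gives > 30000 nM, a limit of the assay.
Compound 2 `COc1ccc(N/C=C\C(=O)c2nc(-c3ccccc3)n3ccccc23)cc1`: in this assay compound 2 gives > 30000 nM, a limit of the assay.
Compound 3 `O=C(/C=C\Nc1cnc2ccccc2c1)c1nc(-c2ccc(C(F)(F)F)cc2)n2ccccc12`: in this assay compound 3 gives > 30000 nM, a limit of the assay.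

The change from compound 1 to compound 2 is 4-methoxyphenyl in place of quinolin-3-yl on an amine nitrogen. The size of this step, a step that the two limits leave unreadable from compound 1 to compound 2, cannot be read, because both values sit at the limit of > 30000 nM in this assay, at which 3 of the 3 values shown sit.

The two cores differ as follows: trifluoromethyl in place of hydrogen on an aromatic carbon. The step that the two limits leave unreadable from compound 1 to compound 3 is equally unreadable, because compound 1 and compound 3 both rest on (the limit of > 30000 nM in this assay, at which 3 of the 3 values shown sit).

Compound 4 `COc1ccc(N/C=C\C(=O)c2nc(-c3ccc(C(F)(F)F)cc3)n3ccccc23)cc1` has not yet been measured. It differs from compound 3 by 4-methoxyphenyl in place of quinolin-3-yl on an amine nitrogen. The place of this change, on an amine nitrogen whose other neighbours are a double-bonded chain carbon, is worded exactly as for the change from compound 1 to compound 2, so it is the same change, made here on the core of compound 3 rather than the core of compound 1.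

Nothing among the three measured compounds shows any value beneath the limit, and the same change made once before gave no readable step. The step from compound 3 to compound 4 is therefore expected to be a step that the limit leaves unreadable from compound 3 to compound 4, essentially no movement. In this assay compound 4 is estimated at 40000 nM, most likely reported again only as a limit, with an expected range from 15000 nM to 100000 nM.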

Compound 4, half-maximal inhibitory concentration: 21800 nM
Beside the measured number, compound 4's estimate is 1.8-fold (0.26 log units) above it; the range from low to high includes it.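

In this assay, among the compounds shown here, compound 4 gives 21800 nM, the only value among the four compounds that is a number and not a limit, and 4-methoxyphenyl in place of quinolin-3-yl on the core of compound 3 gives an at least 1.3-fold lower number from compound 3 to compound 4 (0.13 log units; that floor lies within the scatter), while trifluoromethyl in place of hydrogen, with the (4-methoxyphenyl)amino group in place, gives an at least 1.3-fold lower number from compound 2 to compound 4 (0.13 log units; that floor lies within the scatter). Both steps are floors only: they allow a larger true step but do not show a real difference, and they do not separate the effect of either change from the scatter. Whether the amine change carries from one core to the other stays unsettled, and no size can be set against the step on the core of compound 3, because the steps from compound 1 to compound 2 and from compound 1 to compound 3 cannot be read: the limit of > 30000 nM in this assay, at which 3 of the 4 values shown sit.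

The compounds shown leave open whether a step beyond the scatter appears with a chlorine atom, a nitrile or a carboxylic acid in place of trifluoromethyl. They also leave open what a morpholine or a dimethylamino group on the phenyl ring of the (4-methoxyphenyl)amino group, in place of methoxy, would give.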